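Double-Bond Configuration in a Second Pair of Compounds

This account rests on a few compounds, and the source may have more. Where it says the series, first, only, none or still open, it means among the compounds named here.

In a functional assay on P388 cells (Mus musculus) for cytotoxicity (on this read-out higher numbers stand for weaker inhibition and lower numbers for stronger inhibition), compound 1 `COc1cc(/C=C\c2ccc3ccccc3n2)cc(OC)c1OC` gives 316 nM and compound 2 `COc1cc(/C=C/c2ccc3ccccc3n2)cc(OC)c1OC` gives 398 nM. Compound 3 `COc1cc(/C=C\c2cnc3ccccc3c2)cc(OC)c1OC` gives 398 nM, which matches compound 2 at the digits shown and lies within the scatter of compound 1. All three values therefore sit close together.

The next comparison is with compound 4 `COc1cc(/C=C/c2cnc3ccccc3c2)cc(OC)c1OC`, which has not yet been measured. The structural change is the two compounds have the same atoms and bonds and differ only in configuration as drawn: 1 of 1 stereo elements differ; a double bond is drawn Z in compound 3 and E in compound 4. Among the compounds with values here, only one measured step involves the same kind of change, and it is the one a 1.3-fold higher number from compound 1 to compound 2 (0.10 log units; within the scatter). In that pair, the fact that compounds 1 and 2 differ only in the configuration as drawn defines the comparison, and the step stays small. It is a single example, but it gives no reason to expect a large shift here.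

A small move towards a higher number, not beyond the scatter, is expected for the estimated step of a 1.3-fold higher number from compound 3 to compound 4 (0.10 log units; within the scatter). The expected value for compound 4 is 500 nM, with an estimated range of 220 nM to 1200 nM.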

Compound 4, half-maximal inhibitory concentration: > 3160 nM
Compound 4 was reported as a limit; the forecaster's own chance of this, stated with the estimate: 3%; middle value at least 6.3-fold (0.80 log units) from the limit.
By their numbers in this assay, from the lowest: compounds 1, 2 and 3 (each within the scatter of the next). At a limit, above all of these: compound 4.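

In this assay compound 4 gives > 3160 nM as a limit of the assay, not a number. The change from Z to E that gave a 1.3-fold higher number from compound 1 to compound 2 (0.10 log units; within the scatter) gives an at least 7.9-fold higher number from compound 3 to compound 4 (0.89 log units; beyond the scatter) in the second pair, so this change does not have one size across the two pairs, and compound 2 goes against any general rule that the E form loses activity. Nothing else separates the two members of the second pair: the fact that compounds 3 and 4 differ only in the configuration as drawn.

On these data alone, how far compound 4 lies past its limit remains open, so the full size of its step cannot be read. Also open, as far as these compounds go, is whether a hydroxyl group or an amine on the shared core would leave the gap between the Z and E forms as wide as it is here.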